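Benzyl ring fluorine removal in the trimethoxyphenyl sulfonamide series

This account rests on a few compounds, and the source may have more. Where it says the series, first, only, none or still open, it means among the compounds named here.

Measured so far:
- compound 1, `COc1ccc(CN(c2cc(OC)c(OC)c(OC)c2)S(=O)(=O)c2ccccc2)cc1`: > 50000 nM (a limit)
- compound 2, `COc1ccc(CN(c2cc(OC)c(OC)c(OC)c2)S(=O)(=O)c2c(C)cc(C)cc2C)cc1`: 18700 nM
- compound 3, `COc1cc(N(Cc2ccc(F)cc2)S(=O)(=O)c2ccc(C)cc2)cc(OC)c1OC`: 19200 nM

In a functional assay on MCF7 cells (Homo sapiens) for inhibition, read by MTT assay, with a stated time of 48 h (on this read-out higher numbers stand for weaker inhibition and lower numbers for stronger inhibition), compound 1 reports only a limit, > 50000 nM. Among the measured compounds shown here, compound 2 gives 18700 nM, and the one measured step, an at least 2.6-fold lower number from compound 1 to compound 2 (0.42 log units; beyond the scatter), follows the change of 2,4,6-trimethylphenyl in place of phenyl on the sulfonyl sulfur. Compound 3 gives 19200 nM and sits alongside compound 2, the gap between them within the scatter. The remaining value, that of compound 1, is a limit.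

Compound 4 is `COc1cc(N(Cc2ccccc2)S(=O)(=O)c2ccc(C)cc2)cc(OC)c1OC`. It differs from compound 3 by hydrogen in place of fluoro on an aromatic carbon, on the benzyl ring, para to a large group. For the measured compounds named here, the only measured step, an at least 2.6-fold lower number from compound 1 to compound 2 (0.42 log units; beyond the scatter), concerns the sulfonyl aryl and not the benzyl ring, so it does not bear on this change; no measured pair covers a change at the benzyl ring. With nothing to point either way, the expected step is a 1.0-fold higher number from compound 3 to compound 4 (0.02 log units; within the scatter), none beyond the scatter, with compound 4 expected to stay near compound 3 at 19200 nM. Compound 4 is therefore estimated at 20000 nM, with a range from 8000 nM to 50000 nM.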

Compound 4, half-maximal inhibitory concentration: 10200 nM
Beside the measured number, compound 4's estimate is 2.0-fold (0.29 log units) above it; the range from low to high includes it.
By their numbers in this assay, from the lowest: compounds 4, 2 and 3 (each within the scatter of the next). At a limit, above all of these: compound 1.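

In this assay the benzyl ring now has its first measured pair: hydrogen in place of fluoro on an aromatic carbon, para to a large group, gives a 1.9-fold lower number from compound 3 to compound 4 (0.27 log units; within the scatter) and so no resolved change at this position. With the 4-fluorobenzyl group exchanged for benzyl, compound 4 still gives a finite value of 10200 nM in this assay, which shows that a finite reading in this sulfonamide pair does not depend on the fluoro. The data shown give no cause for this step, and a single pair within the scatter offers no trend to explain.

Going by these compounds, compounds 2 and 4 differ in more than one place, leaving the benzyl and sulfonyl aryl contributions unseparated, and it remains unknown whether the 2,4,6-trimethylphenyl step seen with the 4-methoxybenzyl group would carry over to the 4-fluorobenzyl or benzyl compounds. Also open, on these data alone, is how the series would respond to a clearly different group at this position of the benzyl ring, such as an amine or a carboxylic acid, with the rest of compound 4 held fixed.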